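Benzyl to Butyl at the Cytotoxicity Limit

The source may hold more compounds than are shown below. What is called first, only, known or untested is meant among the compounds shown, and "the series" means these compounds.

Of the compounds shown here, three sharing one core have been tested in an ADME assay on Vero cells (Chlorocebus sabaeus) for cytotoxicity, read by resazurin assay, with a stated time of 3 days (a lower number here means a stronger inhibitor, a higher number a weaker inhibitor), which asks how much of a substance is needed to harm ordinary cells. Compound 1, `CCN(CC)c1cc2[nH]c(C3CCCCC3)nc2cc1NC(=O)NCc1ccccc1`, gives > 100 ug/mL, and this is a limit of the assay rather than a number. Compound 2, `O=C(NCc1ccccc1)Nc1cc2nc(C3CCCCC3)[nH]c2cc1N1CCCC1`, also gives > 100 ug/mL, again only a limit. Compound 3, `CN(C)c1cc2[nH]c(C3CCCCC3)nc2cc1NC(=O)c1ccc(F)cc1F`, gives > 100 ug/mL, which is likewise a limit. Among the measured compounds shown here, the single measured step between close neighbours, a step that the two limits leave unreadable from compound 1 to compound 2, stays unreadable because the limit of > 100 ug/mL in this assay, at which 3 of the 3 values shown sit, places both of its ends at the same ceiling, so no size can be taken from it.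

Compound 4, `CCCCNC(=O)Nc1cc2nc(C3CCCCC3)[nH]c2cc1N1CCCC1`, has not yet been measured. It differs from compound 2 by propyl in place of phenyl on a saturated chain carbon bound to an amide-type nitrogen. For the measured compounds named here, no measured step covers this kind of change, and the one step on record gives no readable size at all. Going by the values given here, compound 2 therefore stands at the limit that every value so far has reached, as the limit of > 100 ug/mL in this assay, at which 3 of the 3 values shown sit, shows. With nothing pointing to a departure, compound 4 is expected to stay at that same limit, and the expected step that the limit leaves unreadable from compound 2 to compound 4 is none beyond the scatter. Compound 4 is accordingly estimated at 150 ug/mL, with a range from 60 ug/mL to 400 ug/mL, and most likely the assay will again report only a limit.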

Compound 4, half-maximal inhibitory concentration: > 100 ug/mL
Compound 4: a limit, no number; the forecaster's own chance of this, stated with the estimate: 80%; the middle value is on the limit's open side.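

In this assay compound 4 gives > 100 ug/mL, which is a limit and not a number. No size can be read for the change from compound 2 to compound 4 because both compounds sit at the same ceiling: the limit of > 100 ug/mL in this assay, at which 4 of the 4 values shown sit.

The compounds shown leave open the concentration at which any of them would harm these cells.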